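The source may hold more compounds than are shown below. What is called first, only, known or untested is meant among the compounds shown, and "the series" means these compounds.

In a functional assay on A-431 cells (Homo sapiens) for antiproliferative activity, read by MTT assay, with a stated time of 72 h (on this read-out higher numbers stand for weaker inhibition and lower numbers for stronger inhibition), compound 2 (`C=CC(=O)Nc1cc2c(Nc3ccc(F)c(Cl)c3)ncnc2cc1OCc1cn(CCC(=O)NO)nn1`) gives 22100 nM and compound 1 (`C=CC(=O)Nc1cc2c(Nc3ccc(OCc4cccc(F)c4)c(Cl)c3)ncnc2cc1OCc1cn(CCCC(=O)NO)nn1`) gives 19900 nM so the two stand level within the usual scatter of such measurements. Compound 3 (`C=CC(=O)Nc1cc2c(Nc3ccc(OCc4cccc(F)c4)c(Cl)c3)ncnc2cc1OCc1cn(CCC(=O)NO)nn1`) follows compound 2 but carries (3-fluorobenzyl)oxy in place of fluoro on an aromatic carbon, ortho to a chloro group. For the measured compounds named here, no measured pair isolates this swap, so its size cannot be read directly from the data. Compound 1 also bears (3-fluorobenzyl)oxy, on a different chain, and its value of 19900 nM stays in the same range as that of compound 2, so no change beyond the scatter is expected in this assay here. The estimated step of a 1.2-fold lower number from compound 2 to compound 3 (0.09 log units; within the scatter) is therefore small and has no clear direction. Compound 3 is estimated at 18000 nM with an expected range from 7000 nM to 45000 nM in this test.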

Compound 3, half-maximal inhibitory concentration: 16300 nM
The estimate for compound 3 lay 1.1-fold (0.04 log units) above the measured number; measured number inside the range.
By their numbers in this assay, from the lowest: compounds 3, 1 and 2 (each within the scatter of the next).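

Compound 1 and compound 2 differ in two places, so only now can each change be read alone. In this assay, putting (3-fluorobenzyl)oxy in place of fluoro, on the aromatic carbon ortho to a chloro group, adds a whole six-membered aromatic ring, yet the result is a 1.4-fold lower number from compound 2 to compound 3 (0.13 log units; within the scatter), and the chain change, hydroxycarbamoyl in place of (hydroxycarbamoyl)methyl, gives a 1.2-fold lower number from compound 1 to compound 3 (0.09 log units; within the scatter), so neither change separates the compounds beyond the scatter. No measurement available here offers an explanation for these small steps.

Still open, going by these compounds, is whether an amine or a carboxylic acid at this aromatic carbon would shift the number beyond the scatter. The same question stands for a longer chain carrying the hydroxycarbamoyl group.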